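Trifluoromethyl in Place of Methyl on Two Cores

A few compounds are considered here, and "the series" means these few. Any claim that something is new, unique, unknown or untested is made for them only; others in the source may bear on it.

Measured so far:
compound 1, `CCOC(=O)N1CCC(=NNC(=O)c2ccc(C)cc2)CC1`: > 400000 nM
compound 2, `CCOC(=O)N1CCC(=NNC(=O)c2ccc(C(F)(F)F)cc2)CC1`: > 400000 nM
compound 3, `Cc1ccc(C(=O)NN=C2CC(c3ccccc3)NC(c3ccccc3)C2)cc1`: > 400000 nM

In a toxicity assay on BJ cells (Homo sapiens) for cytotoxicity, read by MTT assay, with a stated time of 24 h (on this read-out higher numbers stand for weaker inhibition and lower numbers for stronger inhibition), compound 1 gives > 400000 nM, which is a limit of the assay and not a number. Compound 2 gives > 400000 nM in this assay, again a limit. Compound 3 gives > 400000 nM, also a limit. Compound 1 and compound 2 differ by trifluoromethyl in place of methyl on an aromatic carbon, and the resulting step is a step that the two limits leave unreadable from compound 1 to compound 2, since every value shown sits at the limit of > 400000 nM in this assay, at which 3 of the 3 values shown sit. The core of compound 1 and the core of compound 3 are not the same, but the difference between the two cores is not broken down here.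

Compound 4, `O=C(NN=C1CC(c2ccccc2)NC(c2ccccc2)C1)c1ccc(C(F)(F)F)cc1`, has not yet been measured in this assay. It differs from compound 3 by trifluoromethyl in place of methyl on an aromatic carbon, the same change as that from compound 1 to compound 2.

Compound 4 is expected to remain at the limit because compound 1 and compound 2 both sit at the limit of > 400000 nM in this assay, at which 3 of the 3 values shown sit, after this same change. The step expected for compound 4 is a step that the limit leaves unreadable from compound 3 to compound 4. Compound 4 is estimated at 600000 nM, expected to lie between 300000 nM and 2000000 nM.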

Compound 4, half-maximal inhibitory concentration: > 400000 nM
Compound 4 gave a limit, no number; the forecaster's own chance of this, stated with the estimate: 90%; the middle value lies beyond the limit too.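

In this assay compound 4 gives > 400000 nM, which is a limit of the assay and not a number. No step can be read from compound 3 to compound 4, as both compounds stand at a limit: the limit of > 400000 nM in this assay, at which 4 of the 4 values shown sit.

The compounds shown leave open how trifluoromethyl in place of methyl acts on either core in this assay, as none of them gives a number there.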